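Bromo on the Fused Core: Antiproliferative Working Notes

This account rests on a few compounds, and the source may have more. Where it says the series, first, only, none or still open, it means among the compounds named here.

Compound 1 `O=[N+]([O-])c1ccc(Cl)c(/C=C/c2nc3ncccc3[nH]2)c1` gives 61600 nM in an ADME assay on WI-38 cells (Homo sapiens) for antiproliferative activity, read by MTT assay, with a stated time of 72 h; a lower number here means a stronger inhibitor, a higher number a weaker inhibitor. Compound 2 `O=[N+]([O-])c1ccc(Cl)c(/C=C/c2nc3ncc(Br)cc3[nH]2)c1` carries bromo in place of hydrogen on an aromatic carbon and in this assay compound 2 gives 6480 nM; the step is a 9.5-fold lower number from compound 1 to compound 2 (0.98 log units; beyond the scatter). Compound 3 `N#Cc1ccc(/C=C/c2nc3ncccc3[nH]2)cc1` is reported in this assay only as > 100000 nM, which is a limit of the assay and not a number. This is the limit of > 100000 nM in this assay, at which 1 of the 3 values shown sits. The difference between the core of compound 1 and the core of compound 3 is not broken down here. Compound 4 `N#Cc1ccc(/C=C/c2nc3ncc(Br)cc3[nH]2)cc1`, not yet measured, bears the same change as compound 2, namely (bromo in place of hydrogen on an aromatic carbon), at a place described in identical words. On these data alone, for compound 4 the expected step is an at least 3.3-fold lower number from compound 3 to compound 4 (0.52 log units; beyond the scatter), resting on a 9.5-fold lower number from compound 1 to compound 2 (0.98 log units; beyond the scatter) and on compound 3 standing only at a limit, so its true starting value is unknown. Compound 4 is expected to give 30000 nM, likely between 8000 nM and 100000 nM.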

Compound 4, half-maximal inhibitory concentration: 6760 nM
Estimate against measurement, compound 4: 4.4-fold (0.65 log units) above; the measured number lies below the stated range.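

Bromo in place of hydrogen on an aromatic carbon carries over to a second core in this assay, with an at least 14-fold lower number from compound 3 to compound 4 (1.17 log units; beyond the scatter) set beside a 9.5-fold lower number from compound 1 to compound 2 (0.98 log units; beyond the scatter). Compound 3 stands at > 100000 nM, which is a limit of the assay and not a number. The direction of the change is therefore shared by these two cores, but no finding follows on whether its size is the same: the same change on two cores in this assay, a 9.5-fold lower number (0.98 log units; beyond the scatter) from compound 1 to compound 2 and an at least 14-fold lower number (1.17 log units; beyond the scatter) from compound 3 to compound 4; the limit leaves it open whether they differ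

The compounds shown leave open whether an amine or a methoxy group at the same place would also lower the number. On these data alone, whether the bromo change holds on cores other than those of compound 1 and compound 3 also remains open.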